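Hydroxamate series: benzothiophene for methoxyphenyl on the triazole carbon

The compounds below may be only part of what the source reports. "The series", "measured", "known", "first", "only" and "open" are said of these compounds alone.

Three compounds of this series carry numbers in an assay on Sf9 cells for inhibition of protein deacetylase HDAC6 (Homo sapiens), read by fluorescence, with a stated time of 40 min, tested at 100 nM; on this read-out higher numbers stand for more inhibition at the one concentration tested (going by the name of the read-out) and lower numbers for less inhibition. Compound 1 `COc1ccc(-c2nc(CNc3ccc(C(=O)NO)cc3)n(-c3ccccc3)n2)cc1` gives 77.6% and stands highest of the three. Compound 3 `Cc1ccc(-n2nc(-c3ccccc3)nc2CNc2ccc(C(=O)NO)cc2)cc1C` gives 53%, the nearest number to compound 1 yet still lower by a margin beyond the scatter. Compound 2 `CNC(=O)c1ccc(NCc2nc(-c3ccccc3)nn2-c2ccccc2)cc1` gives -3.6%, the furthest from compound 1, again beyond the scatter. No pair among these three differs in a single place, and nothing beyond their three values is said of them here.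

The next compound, compound 4 `O=C(NO)c1ccc(NCc2nc(-c3cc4ccccc4s3)nn2-c2ccccc2)cc1`, awaits measurement in this assay. It differs from compound 1 in one place: 1-benzothiophen-2-yl in place of 4-methoxyphenyl on an aromatic carbon. No step between two measured compounds isolates this change, and its size can only be expected, not read from the numbers shown.

The entering group is again an aromatic ring system, the hydroxamic acid and the rest of compound 1 are kept, and a step of no more than the scatter is expected. In this assay the expected step is a number 7.6 percentage points lower from compound 1 to compound 4 (within the scatter), none beyond the scatter. For compound 4 the expected reading in this assay is 70%, with a range from 45% to 90%.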

Compound 4, a percentage reported as inhibition, at one concentration (the size of the read-out at that concentration, not a potency): 65.5%
Compound 4: the middle estimate sits 4.5 percentage points above what was measured; the measured number falls inside the stated range.
By their numbers in this assay, from the lowest: compound 2; then compound 3; then compound 4; then compound 1.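

In this assay, within the data shown here, putting 1-benzothiophen-2-yl in place of 4-methoxyphenyl on the aromatic carbon between two ring nitrogen atoms gives the first readable step: a number 12.1 percentage points lower from compound 1 to compound 4 (beyond the scatter). The position therefore accepts a group with one five-membered and one six-membered aromatic ring, and with the hydroxamic acid kept, compound 4 still reads 65.5% at the one concentration tested, so the change lowers the number without abolishing the inhibition. Nothing measured here accounts for the step, either through the loss of the methoxy oxygen or through the entry of the sulfur.

A single step at this carbon cannot show whether the fall follows from the second ring, the sulfur or the loss of the methoxy group, and a plain phenyl, a benzofuran-2-yl or a naphthalen-2-yl group would help to separate these. From the compounds shown here alone, it also remains open how far this carbon accepts groups of another kind, such as a pyridine ring, a carboxylic acid or an amine on a short chain.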